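The source may hold more compounds than are shown below. What is called first, only, known or untested is meant among the compounds shown, and "the series" means these compounds.

In an ADME assay on the whole organism (Rattus norvegicus, strain Sprague-Dawley) for pharmacokinetics, read by LC-MS, with a stated time of 30 min, at a dose of 1 mg/kg by the intravenous route (a higher number here means faster removal of the compound, a lower number slower removal), the measured compounds stand as follows:
compound 1 `N#Cc1ccc(O[C@H]2CN(S(=O)(=O)c3ccc(Cl)cc3Cl)C[C@@]2(O)CN)cc1F` gives 1100 mL/min/kg
compound 2 `N#Cc1ccc(O[C@H]2CN(S(=O)(=O)c3ccc(Cl)cc3Cl)C[C@]2(O)CO)cc1F` gives 1350 mL/min/kg
compound 3 `N#Cc1ccc(O[C@H]2CN(S(=O)(=O)c3ccc(Cl)cn3)C[C@@]2(O)CO)cc1F` gives 170 mL/min/kg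

Compound 3 is the lowest of the three. Compound 1 is its nearest neighbour and compound 2 its furthest, and both lie higher by more than the usual scatter. Compound 4 `N#Cc1ccc(O[C@H]2CN(S(=O)(=O)c3ccc(C(F)(F)F)nc3)C[C@@]2(O)CO)cc1F` has 6-(trifluoromethyl)pyridin-3-yl in place of 5-chloropyridin-2-yl on a sulfonyl sulfur and is otherwise the same as compound 3. Within the data shown here, no measured pair isolates this exchange, so the expectation is weakly anchored and its range is wide. In this assay a small upward move is expected, and the estimated step of a 1.5-fold higher number from compound 3 to compound 4 (0.18 log units; within the scatter) stays within the scatter. For compound 4 the estimate is 260 mL/min/kg within an expected range of 90 mL/min/kg to 750 mL/min/kg on present data.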

Compound 4, clearance: 210 mL/min/kg
Compound 4: the middle estimate sits 1.2-fold (0.09 log units) above what was measured; low and high end bracket the measured number.
By their numbers in this assay, from the lowest: compounds 3 and 4 (each within the scatter of the next); then compounds 1 and 2 (each within the scatter of the next).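

In this assay the placing of 6-(trifluoromethyl)pyridin-3-yl in place of 5-chloropyridin-2-yl on a sulfonyl sulfur gives a 1.2-fold higher number from compound 3 to compound 4 (0.09 log units; within the scatter), the only step shown that isolates a single place. At this position, on the core shared by compound 3 and compound 4, a group of 10 heavy atoms thus reads the same as one of 7 within the scatter, with the counts of hydrogen-bond donors and acceptors unchanged. No measurement in hand speaks to the reason for this result.

Still open, from the compounds shown here alone, is whether an aromatic ring carrying a carboxylic acid, or a simple alkyl chain, on the sulfonyl sulfur would also stay within the scatter of compound 3. Also open, going by these compounds, is whether the same exchange would read alike on the core of compound 1.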